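Cytotoxicity Across Two Measured Analogues and One Candidate

The compounds below may be only part of what the source reports. "The series", "measured", "known", "first", "only" and "open" are said of these compounds alone.

Measured compounds:
compound 1 `CN1CCN(CCCNCc2cn(-c3ccc([N+](=O)[O-])cc3)nc2-c2ccc(Cl)cc2)CC1` gives 3700 nM
compound 2 `Cc1ccccc1-c1nn(-c2ccc(Cl)cc2)cc1CNCCN1CCN(C)CC1` gives 17000 nM

In an ADME assay on Huh-7 cells (Homo sapiens) for cytotoxicity (on this read-out lower numbers stand for higher toxicity in this test and higher numbers for lower toxicity in this test), compound 2 stands highest of the two numbers; compound 1 gives a lower number, and that gap lies beyond the scatter. Compound 3 `Cc1ccccc1-c1nn(Cc2ccc(F)cc2)cc1CNCCN1CCN(C)CC1` differs from compound 2 by 4-fluorobenzyl in place of 4-chlorophenyl on an aromatic nitrogen. Among the measured compounds shown here, no measured pair shows this change, so its effect cannot be read from the data. In this assay a step from compound 2 to compound 3 no larger than the scatter is expected, in no clear direction. Compound 3 is expected at 20000 nM, with a range from 7000 nM to 60000 nM. The expected step is a 1.2-fold higher number from compound 2 to compound 3 (0.07 log units; within the scatter).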

Compound 3, half-maximal cytotoxic concentration: > 20000 nM
Compound 3: only a limit was reported; the forecaster's own chance of this, stated with the estimate: 20%; the middle value sits exactly at the limit.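

In this assay, among the compounds shown here, compound 3 gives > 20000 nM, which is a limit of the assay and not a number. 4-Fluorobenzyl in place of 4-chlorophenyl on the aromatic nitrogen gives an at least 1.1-fold higher number from compound 2 to compound 3 (0.07 log units; that floor lies within the scatter), so this position, untested by the earlier compounds, carries the change without a lower number appearing. The true size of the step cannot be read because only a limit stands: the limit of > 20000 nM in this assay, at which 1 of the 3 values shown sits.

The compounds shown leave open whether plain benzyl or 4-chlorobenzyl on the same nitrogen would read alike. They also leave open whether the fluorine plays any part in this result.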